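Exchanging Methoxymethyl for Hydroxymethyl on the Shared Core

The compounds below may be only part of what the source reports. "The series", "measured", "known", "first", "only" and "open" are said of these compounds alone.

Of the compounds shown here, three sharing one core have been read in a functional assay on A549 cells (Homo sapiens) for antiproliferative activity, read by MTT assay, with a stated time of 48 h; on this read-out higher numbers stand for weaker inhibition and lower numbers for stronger inhibition. Compound 1 (`CC(=O)OC/C1=C/C[C@](C)(CCC=C(C)C)/C=C/[C@@H](OC(=O)C=C(C)C)[C@](C)(OC(C)=O)/C=C/C1=O`) gives 15100 nM. Compound 2 (`COC/C1=C/C[C@](C)(CCC=C(C)C)/C=C/[C@@H](OC(=O)C=C(C)C)[C@](C)(OC)/C=C/C1=O`) gives 4180 nM, and compound 3 (`COC/C1=C/C[C@](C)(CCC=C(C)C)/C=C/[C@@H](OC(=O)C=C(C)C)[C@](C)(O)/C=C/C1=O`) gives 3950 nM. These two stand level within the scatter, and both numbers sit well under that of compound 1. Compound 4 (`CO[C@]1(C)/C=C/C(=O)/C(CO)=C\C[C@](C)(CCC=C(C)C)/C=C/[C@H]1OC(=O)C=C(C)C`) has not yet been measured. It departs from compound 2 by hydrogen in place of methyl on an oxygen on a saturated carbon, which turns methoxymethyl to hydroxymethyl. Within the data shown here, one measured step bears on this, the same kind of exchange made at the other methoxy oxygen: a 1.1-fold lower number from compound 2 to compound 3 (0.02 log units; within the scatter). It is a single precedent at a different oxygen, so it guides the expectation only loosely. No shift beyond the scatter is therefore expected, and the estimated change is a 1.1-fold lower number from compound 2 to compound 4 (0.04 log units; within the scatter). For compound 4 the expected value in this assay is 3800 nM, with an estimated range from 1500 nM to 10000 nM.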

Compound 4, half-maximal inhibitory concentration: 14400 nM
Compound 4: the middle estimate sits 3.8-fold (0.58 log units) below what was measured; the whole stated range lies below it.
By their numbers in this assay, from the lowest: compounds 3 and 2 (each within the scatter of the next); then compounds 4 and 1 (each within the scatter of the next).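

In this assay the same exchange of methyl for hydrogen proves not to read alike at the two oxygens: turning methoxymethyl to hydroxymethyl moves the number beyond the scatter (modestly: a 3.4-fold higher number from compound 2 to compound 4 (0.54 log units; beyond the scatter)), while the earlier exchange at the other methoxy oxygen stays within it (a 1.1-fold lower number from compound 2 to compound 3 (0.02 log units; within the scatter)). Among these compounds, the one precedent therefore does not carry over, and this place on the shared core responds to the loss of the methyl where the other oxygen does not. Nothing available explains why the two oxygens differ.

The compounds shown leave open how the number would move with an ethoxymethyl group or an aminomethyl group in this place. They also leave open what hydrogen on both oxygens together would give.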